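Iodo Returns a Halogen to the Core of Compound 2

A few compounds are considered here, and "the series" means these few. Any claim that something is new, unique, unknown or untested is made for them only; others in the source may bear on it.

Going by the values given here, in an assay on cell membranes for displacement of a labelled ligand from Neuronal acetylcholine receptor; alpha4/beta2 (Rattus norvegicus), read by radioligand binding, with a stated time of 30 min (on this read-out higher numbers stand for weaker inhibition and lower numbers for stronger inhibition), compound 2 `c1ccc(C2=NCCCC2)cc1` gives 2080 nM, the lowest of the two numbers measured so far, while compound 1 `Brc1cccc(C2=NCCCC2)c1` gives 5020 nM. Among the compounds with values here, the only step that bears on the change is a 2.4-fold lower number from compound 1 to compound 2 (0.38 log units; beyond the scatter), which removed a halogen from the same place. Compound 3 `Ic1cccc(C2=NCCCC2)c1` carries iodo in place of hydrogen on an aromatic carbon. Because a halogen at that place cost a 2.4-fold lower number from compound 1 to compound 2 (0.38 log units; beyond the scatter), restoring one is expected to raise the number again. For compound 3 the expected step is a 2.4-fold higher number from compound 2 to compound 3 (0.38 log units; beyond the scatter), a modest rise. Compound 3 is therefore estimated at 5000 nM, within a range from 2000 nM to 15000 nM.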

Compound 3, inhibition constant: 3790 nM
Compound 3: middle estimate off by 1.3-fold (0.12 log units), on the high side; measured number inside the range.
By their numbers in this assay, from the lowest: compounds 2, 3 and 1 (each within the scatter of the next, the first and the last beyond it).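

In this assay iodo in place of hydrogen on the aromatic carbon gives a 1.8-fold higher number from compound 2 to compound 3 (0.26 log units; within the scatter), so at this position iodo cannot be told apart from hydrogen, whereas the bromo step was beyond the scatter. Iodo in place of bromo gives a 1.3-fold lower number from compound 1 to compound 3 (0.12 log units; within the scatter), so the two halogens cannot be told apart here either, and iodo sits within the scatter of both neighbours. Nothing given here accounts for this result. Going by these compounds, what an amine or a carboxylic acid would do at this position remains open, as does whether iodo would read the same on another carbon of the ring.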